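Methoxy to chloro on the benzyl group of compound 1

A few compounds are considered here, and "the series" means these few. Any claim that something is new, unique, unknown or untested is made for them only; others in the source may bear on it.

Measured so far in a functional assay on MDA-MB-231 cells (Homo sapiens) for cytotoxicity; a lower number here means a stronger inhibitor, a higher number a weaker inhibitor:
compound 1 `COc1ccc(Cn2cc(/C=N\NC(=O)c3c[nH]c4ccccc34)c3ccccc32)cc1` gives 15100 nM
compound 2 `COc1ccc(Cn2cc(/C=N\NC(=O)c3c[nH]c4ccccc34)c3cc(OC)ccc32)cc1` gives 9800 nM
compound 3 `COc1ccc(Cn2cc(/C=N\NC(=O)c3c[nH]c4ccc(Br)cc34)c3ccc(F)cc32)cc1` gives 99800 nM

Compound 1 stands second highest of the three numbers in this assay; compound 2 lies nearest, and the gap between them, a 1.5-fold lower number from compound 1 to compound 2 (0.19 log units; within the scatter), is within the scatter, so the two read as equal. Going by the values given here, compound 3 is furthest away with the highest number of the set; it differs from compound 1 in more than one place, so its value shows only that the doubly changed analogue is weaker.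

Compound 4 `O=C(N/N=C\c1cn(Cc2ccc(Cl)cc2)c2ccccc12)c1c[nH]c2ccccc12` is not yet measured. Relative to compound 1 the change is chloro in place of methoxy on an aromatic carbon. Among the compounds with values here, no measured pair shows this exchange: the one single step, from compound 1 to compound 2, concerns a methoxy added to the shared core, not the benzyl substituent, and it was within the scatter. With nothing to point either way, no step beyond the scatter is expected in this assay for compound 4, and the estimate for compound 4 is 15000 nM, between 5000 nM and 45000 nM. The step this implies, a 1.0-fold lower number from compound 1 to compound 4 (0.00 log units; within the scatter), is expected to be negligible.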

Compound 4, half-maximal inhibitory concentration: 66400 nM
Estimate against measurement, compound 4: 4.4-fold (0.65 log units) below, and the stated range ends below it.
By their numbers in this assay, from the lowest: compounds 2 and 1 (each within the scatter of the next); then compounds 4 and 3 (each within the scatter of the next).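

In this assay, 4-methoxybenzyl and 4-chlorobenzyl are not interchangeable on the core of compound 1: a 4.4-fold higher number from compound 1 to compound 4 (0.64 log units; beyond the scatter) is a modest step, but it lies beyond the scatter and is the only single change shown that does. This position, on an aromatic carbon para to a large group, therefore responds to the exchange of its substituent, whereas the methoxy added to the shared core, a 1.5-fold lower number from compound 1 to compound 2 (0.19 log units; within the scatter), left the two compounds reading as equal. No measurement on hand bears on what lies behind this step.

From the compounds shown here alone, with a single exchange at this position, it remains open whether the higher number reflects the arrival of chloro or the departure of methoxy, and whether a hydrogen, an amine or a carboxylic acid in the same place would read with compound 1 or with compound 4. Also open, going by these compounds, is whether the same exchange gives a step of similar size on the methoxy-bearing core of compound 2.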